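A few compounds are considered here, and "the series" means these few. Any claim that something is new, unique, unknown or untested is made for them only; others in the source may bear on it.

Measured compounds:
Compound 1, `NC(=S)Nc1cccc(OCCCCCOc2ccccc2)c1`, gives > 50000 nM in an ADME assay on Ava5 cells (Homo sapiens) for cytotoxicity (a lower number here means that less compound is tolerated, a higher number that more compound is tolerated), which is a limit of the assay rather than a number.
Compound 2, `NC(=S)Nc1cccc(OCCCCCOc2ccc(Cl)cc2)c1`, gives 7000 nM in this assay.

Within the data shown here, compound 2 therefore stands as the only measured number in this assay; the other value sits at the limit of > 50000 nM in this assay, at which 1 of the 2 values shown sits. Among the measured compounds shown here, the one measured step, an at least 7.1-fold lower number from compound 1 to compound 2 (0.85 log units; beyond the scatter), came with a chloro in place of hydrogen on an aromatic carbon, so adding the chlorine lowered the tolerated concentration.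

Compound 3, `NC(=S)Nc1cccc(OCCCCCOc2ccncc2)c1`, has not yet been measured. It differs from compound 2 by pyridin-4-yl in place of 4-chlorophenyl on an oxygen on a saturated carbon. The chlorine that came with the measured step leaves here, and a ring nitrogen enters in its place. For the measured compounds named here, only one step bears on this change, and it runs the other way, so the number for compound 3 is expected to rise in this assay, back toward the limit seen for compound 1, with a fair chance that only a limit is reported. The expected step is a 4.3-fold higher number from compound 2 to compound 3 (0.63 log units; beyond the scatter). Compound 3 is estimated at 30000 nM, within a range from 10000 nM to 50000 nM.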

Compound 3, half-maximal cytotoxic concentration: > 50000 nM
Compound 3 gave a limit, no number (the forecaster's own chance of this, stated with the estimate: 40%); middle value at least 1.6-fold (0.22 log units) from the limit.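

Putting pyridin-4-yl in place of 4-chlorophenyl on an oxygen on a saturated carbon gave an at least 7.1-fold higher number from compound 2 to compound 3 (0.85 log units; beyond the scatter) in this assay and so returned the read-out to the assay limit. The first step showed that adding chlorine to the phenyl ring lowers the tolerated concentration; this one shows that a ring with no chlorine but with a ring nitrogen does not bring that lowering with it. Among these compounds only the chlorine-bearing compound 2 gives a real number, and no compound goes against this pattern, while the others share a ceiling: the limit of > 50000 nM in this assay, at which 2 of the 3 values shown sit.

The step between compound 1 and compound 3 cannot be read, since both values are limits, so the phenyl and pyridin-4-yl rings cannot be ranked against each other. Going by these compounds, it also remains open whether the lower number belongs to chlorine itself or would also come with a fluorine, a methyl group or an amine on the phenyl ring, and whether a chlorine on the pyridin-4-yl ring would bring it back.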